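Swapping the Aryl Group on the Isoxazoline Core

A few compounds are considered here, and "the series" means these few. Any claim that something is new, unique, unknown or untested is made for them only; others in the source may bear on it.

Measured so far:
- Compound 1 `COc1ccc(OC)c(C2=NOC(COc3ccc(-c4nnnn4-c4cc(OC)c(OC)c(OC)c4)cc3N)C2)c1`: 3500 nM
- Compound 2 `COc1ccc(C2=NOC(COc3ccc(-c4nnnn4-c4cc(OC)c(OC)c(OC)c4)cc3N)C2)cc1O`: 3380 nM

Both compounds were tested in a functional assay on MDA-MB-231 cells (Homo sapiens) for cytotoxicity, read by MTT assay, with a stated time of 48 h; on this read-out lower numbers stand for stronger inhibition and higher numbers for weaker inhibition. Compound 2 shows the lowest of the two numbers, but the gap to compound 1 is small: a 1.0-fold lower number from compound 1 to compound 2 (0.02 log units; within the scatter). On these two numbers the pair cannot be told apart, so the exchange of 2,5-dimethoxyphenyl for 3-hydroxy-4-methoxyphenyl on the carbon with a double bond to nitrogen left the read-out essentially unchanged.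

Compound 3 `COc1cc(-n2nnnc2-c2ccc(OCC3CC(c4ccc(OC)c(OC)c4OC)=NO3)c(N)c2)cc(OC)c1OC` has not been measured. It differs from compound 2 in one place: 2,3,4-trimethoxyphenyl in place of 3-hydroxy-4-methoxyphenyl on a carbon with a double bond to nitrogen. Going by the values given here, the only step that bears on this change is the one from compound 1 to compound 2, which altered the same aryl group at the same place and stayed within the scatter. A third variation of this group is therefore expected to behave alike, with no step beyond the scatter in this assay in either direction. The estimate for compound 3 is 3400 nM, with a range from 1500 nM to 8000 nM, which means an expected step of a 1.0-fold higher number from compound 2 to compound 3 (0.00 log units; within the scatter).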

Compound 3, half-maximal inhibitory concentration: 3540 nM
Compound 3: middle estimate off by 1.0-fold (0.02 log units), on the low side; the range from low to high includes it.
By their numbers in this assay, from the lowest: compounds 2, 1 and 3 (each within the scatter of the next).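

The 3-hydroxy-4-methoxyphenyl group carries 1 hydrogen-bond donor and 9 heavy atoms, while the 2,3,4-trimethoxyphenyl group carries 0 hydrogen-bond donors and 12 heavy atoms, yet in this assay this exchange gives a 1.0-fold higher number from compound 2 to compound 3 (0.02 log units; within the scatter) and so shows no readable effect of losing that donor. Set against the 2,5-dimethoxyphenyl group, the exchange gives a 1.0-fold higher number from compound 1 to compound 3 (0.00 log units; within the scatter) and again cannot be told apart, which means that all three aryl groups shown on the carbon with a double bond to nitrogen now read alike. Nothing measured here explains why these groups give such similar numbers.

Still open, going by these compounds, is whether a phenyl ring carrying an amine or a carboxylic acid, or a plain methyl group in place of the whole ring, would move the number at this position. All three aryl groups shown carry methoxy groups, so the flat result in this assay describes only this narrow set and cannot be stretched to other kinds of group.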